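The source may hold more compounds than are shown below. What is called first, only, known or untested is meant among the compounds shown, and "the series" means these compounds.

Working notes on the series in a functional assay on PC-3 cells (Homo sapiens) for cytotoxicity, read by colorimetric assay; on this read-out lower numbers stand for stronger inhibition and higher numbers for weaker inhibition.

Two compounds have numbers. Compound 1 `O=C(NO)c1ccc(CN2C(=O)/C(=C3\Nc4ccccc4\C3=N/O)c3cc(Cl)ccc32)cc1` gives 50 nM in this assay. Compound 2 `COc1ccc2c(c1)/C(=C1/Nc3ccccc3/C1=N\O)C(=O)N2Cc1ccc(/C=C/C(=O)NO)cc1` gives 30 nM in this assay. Compound 2 holds the lower of the two numbers, but compound 1 is within the scatter of it, so the two compounds cannot be told apart on this read-out, and no order between them is claimed.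

Compound 3 `COc1ccc2c(c1)/C(=C1/Nc3ccccc3/C1=N\O)C(=O)N2Cc1ccc(C(=O)NO)cc1` has not been measured. It differs from compound 2 in one place: hydroxycarbamoyl in place of 2-(hydroxycarbamoyl)ethenyl on an aromatic carbon. Compound 1 already carries the hydroxycarbamoyl group on its ring, with a different substituent on the shared core, and its number in this assay sits within the scatter of compound 2. Among the measured compounds shown here, no step between measured compounds isolates this change, so the expectation rests on the two numbers alone.

The step from compound 2 to compound 3 is expected to be a 1.5-fold higher number from compound 2 to compound 3 (0.18 log units; within the scatter), that is, no change beyond the scatter in either direction. Compound 3 is therefore estimated at 45 nM in this assay, with a range from 15 nM to 140 nM.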

Compound 3, half-maximal inhibitory concentration: 30 nM
For compound 3 the middle estimate is 1.5-fold (0.18 log units) above the measured one; low and high end bracket the measured number.
By their numbers in this assay, from the lowest: compounds 2, 3 and 1 (each within the scatter of the next).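

In this assay the change at the aromatic carbon para to a large group, from 2-(hydroxycarbamoyl)ethenyl to hydroxycarbamoyl, gives no change at the digits printed from compound 2 to compound 3 (within the scatter). With the methoxy-bearing shared core held fixed, this isolates the change that compound 1 could only suggest: on this read-out, the ethenyl-containing group with 6 heavy atoms and the hydroxycarbamoyl group with 4 cannot be told apart. The same measurement supplies a second single-place comparison, methoxy in place of chloro on an aromatic carbon with hydroxycarbamoyl held constant, which gives a 1.7-fold lower number from compound 1 to compound 3 (0.22 log units; within the scatter), and no evidence bearing on either result is available.

The compounds shown leave open whether this flat picture extends to a carboxylic acid or a longer chain in place of the hydroxycarbamoyl-bearing group, since every compound here keeps a hydroxycarbamoyl end. They also leave open whether an amine or a fluoro group on the shared core, in place of methoxy or chloro, would produce a step beyond the scatter in this assay.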